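The source may report more compounds than this note shows. Statements on the series, on what has been measured and on what is new or still open speak of the compounds shown alone.

Of the compounds shown here, three have been measured in a functional assay on the whole organism (strain albino) for inhibition, with Rattus norvegicus as the target, read by paw edema, with stated times of 30 min and 1 h, at a dose of 100 mg/kg by the oral route; on this read-out lower numbers stand for less inhibition and higher numbers for more inhibition at the one dose given (going by the name of the read-out). Going by the values given here, compound 1 `Nc1ccc(C(=O)/C=C/c2ccc(Cl)cc2)cc1` gives 41%, and compound 2 `Nc1ccc(C(=O)/C=C/c2ccco2)cc1` gives 33%; no step between these two is worked out here, so their values are simply set side by side. Among the compounds with values here, compound 3 `O=C(CBr)Nc1ccc(C(=O)/C=C/c2ccc(Cl)cc2)cc1` gives 44%, and the one step that has been traced is a number 3 percentage points higher from compound 1 to compound 3 (within the scatter), a change that does not leave the scatter.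

Compound 3 thus stands at the top of the three numbers, but only the gap to compound 2 lies beyond the scatter; the gap to compound 1 does not.

Compound 4 `COc1ccc(/C=C/C(=O)c2ccc(NC(=O)CBr)cc2)cc1` differs from compound 3 by methoxy in place of chloro on an aromatic carbon. Within the data shown here, no measured step touches this position on the aromatic ring: the only traced step concerns the nitrogen, and compound 2 differs from compound 1 in a whole ring, not in this one group. With nothing to point either way, the expected step is a number 2 percentage points lower from compound 3 to compound 4 (within the scatter), that is, no movement beyond the scatter. Compound 4 is therefore estimated to give 42%, with a range from 30% to 54%.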

Compound 4, a percentage reported as inhibition, in the whole organism at one dose (the size of the read-out at that dose, not a potency): 37%
Compound 4: the middle estimate sits 5 percentage points above what was measured; low and high end bracket the measured number.
By their numbers in this assay, from the lowest: compounds 2, 4, 1 and 3 (each within the scatter of the next, the first and the last beyond it).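

Going by these compounds alone, at this place on the six-membered aromatic ring, para to a large group, the compounds now give a first traced step in this assay: methoxy in place of chloro gives a number 7 percentage points lower from compound 3 to compound 4 (within the scatter), whereas the earlier step concerned only the nitrogen. The result shows that exchanging chloro, with 1 heavy atom and 0 hydrogen-bond acceptors, for methoxy, with 2 heavy atoms and 1 hydrogen-bond acceptor, does not move this read-out beyond the scatter in this one pair. No measured information bears on why the step has this size.

From the compounds shown here alone, it remains open whether methoxy in place of chloro gives a similar step when the nitrogen carries only hydrogen, as in compound 1, and what a hydroxy group, a carboxylic acid or a dimethylamino group would give at the same position. Because this single pair rests on one oral dose, the compounds shown also leave open how compound 3 and compound 4 would compare at any other dose.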